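The source may hold more compounds than are shown below. What is called first, only, known or untested is meant among the compounds shown, and "the series" means these compounds.

Compound 1 `Cn1ccc2c(Oc3ccc(NC(=O)c4nn(-c5ccc(Br)cc5)ccc4=O)cc3)ccnc21`: 39200 nM
Compound 2 `Cn1ccc2c(Oc3ccc(NC(=O)c4nn(-c5ccccc5)ccc4=O)cc3)ccnc21`: 56200 nM
Compound 3 `Cn1ccc2c(Oc3ccc(NC(=O)c4nn(-c5ccc(Cl)c(C(F)(F)F)c5)ccc4=O)cc3)ccnc21`: 23400 nM

In a functional assay on HepG2 cells (Homo sapiens) for cytotoxicity, read by MTT assay, with a stated time of 72 h (on this read-out higher numbers stand for weaker inhibition and lower numbers for stronger inhibition), compound 2 stands at the highest of the three numbers. The step of a 1.4-fold higher number from compound 1 to compound 2 (0.16 log units; within the scatter) lies within the scatter, whereas a 2.4-fold lower number from compound 2 to compound 3 (0.38 log units; beyond the scatter) reaches beyond it. Compound 4 `Cn1ccc2c(Oc3ccc(NC(=O)c4nn(-c5ccccc5)ccc4=O)cc3F)ccnc21` differs from compound 2 by fluoro in place of hydrogen on an aromatic carbon. Within the data shown here, none of the measured steps touches this position: each of them changes only the group on the aromatic nitrogen, so no measured step bears directly on the change from compound 2 to compound 4. On that basis no shift beyond the scatter is expected in this assay, and the step of a 1.1-fold lower number from compound 2 to compound 4 (0.05 log units; within the scatter) is an estimate of no real change. Compound 4 is therefore expected to give about 50000 nM, within a range from 20000 nM to 110000 nM.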

Compound 4, half-maximal inhibitory concentration: > 60000 nM
Compound 4 gave a limit, no number; the forecaster's own chance of this, stated with the estimate: 15%; middle value at least 1.2-fold (0.07 log units) away from the limit.
By their numbers in this assay, from the lowest: compounds 3, 1 and 2 (each within the scatter of the next, the first and the last beyond it). At a limit, above all of these: compound 4.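

In this assay, among these compounds, fluoro at this position, ortho to a large group and meta to a large group, is read for the first time, and compound 4 gives > 60000 nM as a limit and no number. The step is an at least 1.0-fold higher number from compound 2 to compound 4 (0.02 log units; that floor lies within the scatter) and so sets only a floor, leaving the size of the change unknown. Compound 4 is the only compound shown that sits at a limit: the limit of > 60000 nM in this assay, at which 1 of the 4 values shown sits.

The compounds shown leave open how a chloro, methoxy or amine group would read at this position. They also leave open whether fluoro here would read the same with the 4-bromophenyl group in place of phenyl.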